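Hydroxymethyl to dimethylamino on the piperidine carbonyl

The source may report more compounds than this note shows. Statements on the series, on what has been measured and on what is new or still open speak of the compounds shown alone.

Of the compounds shown here, two have been measured so far. Compound 1 `CCOC(=O)N1CCC(NS(=O)(=O)c2ccc(OC(=O)c3ccccc3)c3ccccc23)CC1` gives 16.4 nM in an assay on L1.2 cells for binding affinity to C-C chemokine receptor type 8 (Homo sapiens); on this read-out higher numbers stand for weaker inhibition and lower numbers for stronger inhibition. Compound 2 `Cc1ccccc1C(=O)Nc1ccc(S(=O)(=O)NC2CCN(C(=O)CO)CC2)c2ccccc12` stands lowest of the two numbers in this assay, at 5.4 nM, and compound 1 sits at a number higher by a margin beyond the usual scatter. Compound 3 `Cc1ccccc1C(=O)Nc1ccc(S(=O)(=O)NC2CCN(C(=O)N(C)C)CC2)c2ccccc12` is not yet measured. It differs from compound 2 in one place: dimethylamino in place of hydroxymethyl on a carbonyl carbon. Cut one bond further out, the change reads 1-((hydroxymethyl)carbonyl)piperidin-4-yl to 1-(dimethylcarbamoyl)piperidin-4-yl, the carbonyl carbon keeping its amide-type nitrogen in a ring as its other neighbour. Within the data shown here, no measured pair in the set shows this change, so its size cannot be read from the data. The expectation for compound 3 in this assay is a step of a 1.3-fold higher number from compound 2 to compound 3 (0.11 log units; within the scatter), within the scatter or at most slightly weaker. Compound 3 is expected to give 7 nM, in the range 2.5 nM to 20 nM.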

Compound 3, inhibition constant: 1.6 nM
The estimate for compound 3 lay 4.4-fold (0.64 log units) above the measured number, outside the stated range (below it).
By their numbers in this assay, from the lowest: compound 3; then compound 2; then compound 1.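

In this assay, dimethylamino in place of hydroxymethyl on a carbonyl carbon gives a 3.4-fold lower number from compound 2 to compound 3 (0.53 log units; beyond the scatter), so this position is not merely tolerant of the change: the number improves. Hydroxymethyl carries a hydrogen-bond donor and acceptor and dimethylamino carries neither, so in this pair a low number does not depend on either of them being present in the group. Nothing measured on these compounds accounts for the size or direction of the step.

Still open, on these data alone, is whether the step follows from the nitrogen on the carbonyl or from the loss of the hydroxyl; methoxymethyl and methylamino at the same place would separate the two. A single pair also leaves open whether larger groups, such as a pyrrolidine on the carbonyl, continue the trend.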